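Extending the urea chain from ethyl to propyl

This account rests on a few compounds, and the source may have more. Where it says the series, first, only, none or still open, it means among the compounds named here.

Compound 1, `CC(C)c1ccccc1OS(=O)(=O)c1ccc(NC(=O)C(C)(C)C)cc1`, gives 15000 nM in a functional assay on HT-29 cells (Homo sapiens) for antiproliferative activity, read by sulforhodamine B assay, with a stated time of 48 h; a lower number here means a stronger inhibitor, a higher number a weaker inhibitor.
Compound 2, `CCNC(=O)Nc1ccc(S(=O)(=O)Oc2ccccc2C(C)C)cc1`, gives 1100 nM in this assay.

For the measured compounds named here, compound 2 has the lowest of the two numbers; the only step in hand, a 14-fold lower number from compound 1 to compound 2 (1.13 log units; beyond the scatter), is a large one. Compound 3, `CCCNC(=O)Nc1ccc(S(=O)(=O)Oc2ccccc2C(C)C)cc1`, differs from compound 2 by methyl in place of hydrogen on a saturated chain carbon, two bonds along the chain from an amide-type nitrogen. That measured step exchanged the whole group on the carbonyl carbon and so does not speak directly to a one-carbon lengthening; no step beyond the scatter is expected in this assay. Compound 3 is therefore estimated at 1000 nM, within 350 nM to 3000 nM, an expected 1.1-fold lower number from compound 2 to compound 3 (0.04 log units; within the scatter).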

Compound 3, half-maximal inhibitory concentration: 6300 nM
For compound 3 the middle estimate is 6.3-fold (0.80 log units) below the measured one; the measured number lies above the stated range.
By their numbers in this assay, from the lowest: compound 2; then compound 3; then compound 1.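

At this saturated chain carbon, two bonds along the chain from an amide-type nitrogen, one added methyl is not a neutral change: going from ethylamino to propylamino gives a 5.7-fold higher number from compound 2 to compound 3 (0.76 log units; beyond the scatter). Most of the gain seen with ethylamino is lost, though propylamino still holds an edge over tert-butyl on the carbonyl carbon, with a 2.4-fold lower number from compound 1 to compound 3 (0.38 log units; beyond the scatter). Nothing available here explains this sensitivity to chain length.

From the compounds shown here alone, it remains open whether methylamino or branched isopropylamino would match ethylamino, and whether a longer chain such as butylamino would raise the number further.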